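Replacing the 1H-tetrazol-5-yl group of compound 2

A few compounds are considered here, and "the series" means these few. Any claim that something is new, unique, unknown or untested is made for them only; others in the source may bear on it.

Compound 1 `CCCCCNC(=O)NCCCC/C=C\CCCCCCCc1nnn[nH]1`: 1100 nM
Compound 2 `CCCCNC(=O)C(=O)NCCCC/C=C\CCCCCCc1nnn[nH]1`: 1700 nM

Both compounds were tested in a functional assay on Coronary artery (Bos taurus); on this read-out higher numbers stand for an effect only at larger amounts of compound and lower numbers for an effect already at smaller amounts. There, compound 2 stands at 1700 nM and compound 1 at 1100 nM, so the two lie within the usual scatter of each other. Compound 3 `CCCCNC(=O)C(=O)NCCCC/C=C\CCCCCCc1noc(=S)[nH]1` has not yet been measured. It departs from compound 2 in one place: a group of 6 heavy atoms (2 carbon, 2 nitrogen, 1 oxygen, 1 sulfur; one five-membered aromatic ring with 3 hetero atoms) in place of a group of 5 heavy atoms (1 carbon, 4 nitrogen; one five-membered aromatic ring with 4 hetero atoms), on a saturated chain carbon, six bonds along the chain from a double-bonded chain carbon. The 1H-tetrazol-5-yl group gives way to a five-membered aromatic ring with 3 hetero atoms, which carries the sulfur. Going by the values given here, no measured pair shows what such an exchange does, so the starting point is simply compound 2 at 1700 nM. The expectation is no shift beyond the scatter, in either direction, with an estimated 1.1-fold lower number from compound 2 to compound 3 (0.05 log units; within the scatter). For compound 3 the expected value is 1500 nM, with an estimated range from 400 nM to 5000 nM.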

Compound 3, half-maximal effective concentration: 360 nM
For compound 3 the middle estimate is 4.2-fold (0.62 log units) above the measured one; measured number outside the range, below it.
By their numbers in this assay, from the lowest: compound 3; then compounds 1 and 2 (each within the scatter of the next).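

In this assay, exchanging the 1H-tetrazol-5-yl group for the five-membered aromatic ring that carries the sulfur gives a 4.7-fold lower number from compound 2 to compound 3 (0.67 log units; beyond the scatter), the only step shown here. This position is therefore not indifferent to which ring it carries, and the 1H-tetrazol-5-yl group is not needed for an effect on this read-out. The two groups have the same tally of hydrogen-bond donors and acceptors, so that tally does not separate them, and no measurement offered here accounts for the step.

The compounds shown leave open whether the sulfur itself matters, since the same ring with a carbonyl oxygen in its place does not appear among them, and neither does a carboxylic acid at this position. They also leave open whether the exchange would have a similar effect on the core of compound 1.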